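The compounds below may be only part of what the source reports. "The series", "measured", "known", "first", "only" and "open" are said of these compounds alone.

Compound 1, `COc1cccc2[nH]c(C(=O)N[C@@H](CC(C)C)C(=O)N[C@H](C#N)C[C@@H]3CCCNC3=O)cc12`, in a toxicity assay on A549 cells (Homo sapiens) for cytotoxicity, read by CellTiter-Glo (a lower number here means that less compound is tolerated, a higher number that more compound is tolerated), gives > 200000 nM, which is a limit of the assay.
Compound 2, `CCOc1cccc2[nH]c(C(=O)N[C@@H](CC(C)C)C(=O)N[C@H](C#N)C[C@@H]3CCCNC3=O)cc12`, in this assay gives > 200000 nM, again a limit.
Compound 3, `COc1cc(Cl)cc2[nH]c(C(=O)N[C@@H](CC(C)(C)C)C(=O)N[C@H](C#N)C[C@@H]3CCCNC3=O)cc12`, in this assay gives > 200000 nM, also a limit.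

Compound 2 thus stands at the limit in this assay, as do the other two measured compounds. Going by the values given here, the single step between measured compounds that differ in one place, a step that the two limits leave unreadable from compound 1 to compound 2, cannot be read because of the limit of > 200000 nM in this assay, at which 3 of the 3 values shown sit; the change from compound 1 to compound 2 is methyl in place of hydrogen on a saturated chain carbon bound to an oxygen on an aromatic ring. Compound 4, `CC(C)C[C@H](NC(=O)c1cc2c(OC(F)(F)F)cccc2[nH]1)C(=O)N[C@H](C#N)C[C@@H]1CCCNC1=O`, is not yet measured. It differs from compound 2 by trifluoromethyl in place of ethyl on an oxygen on an aromatic ring, which cut one bond further out reads ethoxy to trifluoromethoxy. Among the compounds with values here, no measured step gives a readable size, so no step beyond the scatter is expected; the estimated step of a number no higher from compound 2 to compound 4 (the limit leaves the size open) is expected to be none. Compound 4 is therefore expected to give 200000 nM in this assay, within 100000 nM to 200000 nM, most likely reported as a limit.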

Compound 4, half-maximal cytotoxic concentration: 90000 nM
Compound 4: the middle estimate sits 2.2-fold (0.35 log units) above what was measured; the measured number lies below the stated range.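

In this assay the group on this oxygen on an aromatic ring can shift the number: trifluoromethyl in place of ethyl gives an at least 2.2-fold lower number from compound 2 to compound 4 (0.34 log units; beyond the scatter) and trifluoromethyl in place of methyl gives an at least 2.2-fold lower number from compound 1 to compound 4 (0.34 log units; beyond the scatter) at the same place. Compound 4 gives 90000 nM as a measured number and not a limit, whereas the step from methyl to ethyl at this place cannot be read. The full size of both new steps stays open: the limit of > 200000 nM in this assay, at which 3 of the 4 values shown sit.

From the compounds shown here alone, it remains open whether a longer chain such as propoxy, a hydroxyl or an amine in place of ethoxy would also give a number rather than a limit. Going by these compounds, it is also open whether difluoromethyl on the same oxygen would give a number of the same order as trifluoromethyl.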